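Dimethylcarbamoyl for methylsulfonyl on a ketone-bearing oxazole

The source may report more compounds than this note shows. Statements on the series, on what has been measured and on what is new or still open speak of the compounds shown alone.

Compound 1 `O=C(CCCCCc1ccccc1)c1nc2c(F)cccc2o1` in an assay on HEK-293T cells for inhibition of diacylglycerol lipase-alpha (Homo sapiens), read by colorimetric assay; on this read-out higher numbers stand for weaker inhibition and lower numbers for stronger inhibition: 117 nM
Compound 2 `CS(=O)(=O)c1coc(C(=O)CCCCCCc2ccccc2)n1` in this assay: 389 nM

Of the compounds shown here, two have been measured in this assay. Compound 2 gives the higher of the two numbers; its nearest neighbour is compound 1, whose number is lower by a margin that lies beyond the usual scatter. The two compounds differ in more than one place, so nothing more is said about what sets them apart.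

Compound 3 `CN(C)C(=O)c1coc(C(=O)CCCCCCc2ccccc2)n1` is the next compound. It follows from compound 2 by one change: dimethylcarbamoyl in place of methylsulfonyl on an aromatic carbon. The group changes on an aromatic carbon of the five-membered ring, two ring bonds from the ring atom that bears the large ketone-linked chain.

Among the measured compounds shown here, no step of this kind appears among the measured compounds, so the expectation rests on compound 2 alone. The exchange of one neutral, uncharged group for another of similar size is expected to move the number little, if at all, so the step from compound 2 to compound 3 is estimated as a 1.3-fold higher number from compound 2 to compound 3 (0.11 log units; within the scatter), within or near the scatter. Compound 3 is therefore expected to give about 500 nM in this assay, with a range from 150 nM to 1800 nM.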

Compound 3, half-maximal inhibitory concentration: 3390 nM
Compound 3: the middle estimate sits 6.8-fold (0.83 log units) below what was measured, and the stated range ends below it.
By their numbers in this assay, from the lowest: compound 1; then compound 2; then compound 3.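

In this assay the exchange of methylsulfonyl for dimethylcarbamoyl on the aromatic carbon next to the ring nitrogen gives an 8.7-fold higher number from compound 2 to compound 3 (0.94 log units; beyond the scatter) and so lies beyond the scatter, which shows that the number at this position depends strongly on which of these two groups is present. The two groups are close in their counts, with 4 heavy atoms in methylsulfonyl and 5 in dimethylcarbamoyl, and neither has a hydrogen-bond donor or a net charge, so a match in these counts does not keep the number in place in this pair. Nothing measured on these compounds explains the step.

Still open, from the compounds shown here alone, is whether the step belongs to the carbonyl of the new group or to its two methyl groups on nitrogen, a question that an unsubstituted carboxamide or a methyl ester on the same aromatic carbon could answer, and whether a nitrile there would stay close to compound 2. Also open, going by these compounds, is whether the same exchange gives a step of similar size with a shorter chain on the ketone, since compound 2 and compound 3 share one chain.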